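The compounds below may be only part of what the source reports. "The series", "measured", "known", "first", "only" and "open" are said of these compounds alone.

Compound 3, `CCC(CC)c1ccc2c(NCCCNCc3cccc(OC)c3O)ccnc2c1`, stands lowest of the three compounds measured in an ADME assay for permeability, using PAMPA, with a stated time of 30 min, at pH 7.4; on this read-out higher numbers stand for higher permeability and lower numbers for lower permeability. Compound 3 gives 23 10^-6 cm/s, while compound 1, `c1ccc(-c2ccc3c(NCCCNCc4ccco4)ccnc3c2)cc1`, gives 237 10^-6 cm/s and compound 2, `COc1cccc(CNCCCNc2ccnc3cc(Oc4ccc(F)cc4)ccc23)c1O`, gives 317 10^-6 cm/s. The unmeasured compound 4, `COc1cccc(CNCCCNc2ccnc3cc(-c4ccccc4)ccc23)c1O`, differs from compound 3 in one place: phenyl in place of pentan-3-yl on an aromatic carbon. For the measured compounds named here, one measured step bears on this change. It is a 14-fold lower number from compound 2 to compound 3 (1.14 log units; beyond the scatter), and there the pentan-3-yl that compound 4 now loses came in for an aromatic group on the same carbon. Compound 1 also carries a phenyl in this position and reads well above compound 3. On that basis compound 4 is expected to move back up, a step beyond the scatter and in the direction of higher permeability, with the expected step being a 10-fold higher number from compound 3 to compound 4 (1.00 log units; beyond the scatter). Compound 4 is therefore estimated at 230 10^-6 cm/s in this assay, within a range of 120 10^-6 cm/s to 400 10^-6 cm/s.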

Compound 4, apparent permeability: 237 10^-6 cm/s
Beside the measured number, compound 4's estimate is 1.0-fold (0.01 log units) below it; the range from low to high includes it.
By their numbers in this assay, from the lowest: compound 3; then compounds 1, 4 and 2 (each within the scatter of the next).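

In this assay phenyl in place of pentan-3-yl on this aromatic carbon gives a 10-fold higher number from compound 3 to compound 4 (1.01 log units; beyond the scatter) and so makes a second direct comparison: the low reading of compound 3 goes with pentan-3-yl, not with the 2-hydroxy-3-methoxyphenyl group it shares with compound 4. Phenyl and 4-fluorophenoxy on this carbon cannot be told apart, with a 1.3-fold lower number from compound 2 to compound 4 (0.13 log units; within the scatter) in the record, so the plain ring serves as well here as the ring carrying fluorine. With phenyl in place, the swap of furan-2-yl for 2-hydroxy-3-methoxyphenyl on the saturated chain carbon gives no change at the digits printed from compound 1 to compound 4 (within the scatter) and leaves no mark on this read-out.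

No measurement shown gives a reason for the gap between pentan-3-yl and phenyl. As far as these compounds go, it also stays open whether a saturated ring such as cyclohexyl, or a smaller branched group such as isopropyl, on this carbon would read with compound 3 or with compound 4.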